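Oxime for acetyl on the shared core: working notes

This account rests on a few compounds, and the source may have more. Where it says the series, first, only, none or still open, it means among the compounds named here.

Values in an ADME assay on MT4 cells (Homo sapiens) for cytotoxicity, read by MTT assay, with a stated time of 96 h; on this read-out lower numbers stand for higher toxicity in this test and higher numbers for lower toxicity in this test:
- compound 1 `COc1ccc(-c2nc3cc(C(C)=O)ccc3[nH]2)c(OC)c1`: 50000 nM
- compound 2 `COc1ccc(-c2nc3cc(C(C)=O)ccc3[nH]2)c(OC)c1OC`: > 100000 nM (a limit)
- compound 3 `COc1ccc(-c2nc3cc(C(C)O)ccc3[nH]2)cc1`: >= 100000 nM (a limit)

In this assay, within the data shown here, compound 1 gives 50000 nM, the only exact number so far. For compound 2 the entry > 100000 nM is a limit. For compound 3 the entry >= 100000 nM is also a limit.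

Compound 4 `COc1ccc(-c2nc3cc(/C(C)=N/O)ccc3[nH]2)c(OC)c1` is still to be measured. It differs from compound 1 at the acetyl: a group of 4 heavy atoms (2 carbon, 1 nitrogen, 1 oxygen; no ring) in place of a group of 3 heavy atoms (2 carbon, 1 oxygen; no ring), on an aromatic carbon. The rest of the core of compound 1 stays unchanged.

Among the measured compounds shown here, only one measured step is available, an at least 2.0-fold higher number from compound 1 to compound 2 (0.30 log units; that floor lies within the scatter). That step leaves the acetyl in place, and its floor lies within the scatter, so it gives no size for the change at hand. For the measured compounds named here, no measured step replaces the acetyl by another group while all else stays the same. Going by the values given here, with no evidence for a shift in either direction, the expectation stays close to the only exact number. The expected step is a 1.1-fold lower number from compound 1 to compound 4 (0.05 log units; within the scatter), which means no change beyond the scatter. For compound 4 the estimated value in this assay is 45000 nM, with an expected range of 15000 nM to 100000 nM.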

Compound 4, half-maximal cytotoxic concentration: >= 100000 nM
Compound 4: no number, only a limit; the forecaster's own chance of this, stated with the estimate: 30%; at least 2.2-fold (0.34 log units) between middle value and limit.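

Among these compounds, this is the first measured step at the acetyl itself, on the aromatic carbon of the shared core: in this assay, the group with 1 hydrogen-bond donor and 2 hydrogen-bond acceptors in place of the acetyl gives an at least 2.0-fold higher number from compound 1 to compound 4 (0.30 log units; that floor lies within the scatter). The step has only a floor, and that floor stays within the scatter, so the position shows no change beyond the scatter, while a larger one is not ruled out. The value of compound 4 is a limit, so this change gives no second exact number for the series: the limit of >= 100000 nM in this assay, at which 2 of the 4 values shown sit.

From the compounds shown here alone, the true size of the step remains open, and no comparison at this position yet rests on two exact numbers. Also open, going by these compounds, is whether an amine or a carboxylic acid in place of the acetyl would give an exact number in this assay that differs beyond the scatter from that of compound 1, and so show whether this position affects the read-out at all.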